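Adding a Methyl to the Piperidine Ring of Compound 3

This account rests on a few compounds, and the source may have more. Where it says the series, first, only, none or still open, it means among the compounds named here.

Compound 1 `COc1cc2c(Oc3ccc(NC(=O)c4nn(-c5ccccc5C)c(=O)cc4C)cc3F)ccnc2cc1OCCCN1CCC(C)CC1`: 2260 nM
Compound 2 `COc1cc2c(Oc3ccc(NC(=O)c4nn(-c5ccccc5C(F)(F)F)c(=O)cc4C)cc3F)ccnc2cc1OCCCN1CCCC1`: 210 nM
Compound 3 `COc1cc2c(Oc3ccc(NC(=O)c4nn(-c5ccccc5C(F)(F)F)c(=O)cc4C)cc3F)ccnc2cc1OCCCN1CCCCC1`: 210 nM

In a functional assay on NCI-H460 cells (Homo sapiens) for inhibition, read by MTT assay, with a stated time of 72 h (a higher number here means a weaker inhibitor, a lower number a stronger inhibitor), compound 3 stands level with compound 2, and the two share the lowest number of the three; compound 1, which carries a methyl rather than a trifluoromethyl on its phenyl ring, lies well above both, beyond the scatter. Compound 4 `COc1cc2c(Oc3ccc(NC(=O)c4nn(-c5ccccc5C(F)(F)F)c(=O)cc4C)cc3F)ccnc2cc1OCCCN1CCC(C)CC1` differs from compound 3 only by methyl in place of hydrogen on a saturated ring carbon. Among the measured compounds shown here, the one step that touches this part of the molecule, no change at the digits printed from compound 2 to compound 3 (within the scatter), changed the size of the amine ring without any effect. A methyl on that ring is a further small change in the same region, so no step beyond the scatter is expected: a 1.1-fold higher number from compound 3 to compound 4 (0.06 log units; within the scatter). Compound 4 is therefore estimated at 240 nM, in the range 100 nM to 600 nM.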

Compound 4, half-maximal inhibitory concentration: 200 nM
Beside the measured number, compound 4's estimate is 1.2-fold (0.08 log units) above it, and the stated range covers the measured number.
By their numbers in this assay, from the lowest: compounds 4, 2 and 3 (each within the scatter of the next); then compound 1.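

In this assay, the methyl on the piperidine ring leaves the number within the scatter, with a 1.1-fold lower number from compound 3 to compound 4 (0.02 log units; within the scatter), and replacing pyrrolidin-1-yl with 4-methylpiperidin-1-yl does the same, with a 1.1-fold lower number from compound 2 to compound 4 (0.02 log units; within the scatter). The 4-methylpiperidin-1-yl group is shared by compound 1 and compound 4. The trifluoromethyl in place of methyl on the phenyl ring can now be read alone, and it gives an 11-fold lower number from compound 1 to compound 4 (1.05 log units; beyond the scatter). Nothing available explains either result. Still open, from the compounds shown here alone, is whether a hydroxyl or a phenyl on the same saturated ring carbon would be accommodated equally well. Going by these compounds, a chlorine in place of the trifluoromethyl also remains untested in these compounds.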